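The source may report more compounds than this note shows. Statements on the series, on what has been measured and on what is new or still open speak of the compounds shown alone.

Compound 1 `OCCCCCC(O)c1ccc(-c2ccccc2)cc1` and compound 2 `Cc1ccccc1-c1ccc(C(O)CCCCCO)cc1` share one core and were both tested in a functional assay on J774 cells (Mus musculus) for cytotoxicity, read by resazurin assay; on this read-out lower numbers stand for stronger inhibition and higher numbers for weaker inhibition. In this assay compound 1 gives 22000 nM, and compound 2 gives 24000 nM. The change between them, (methyl in place of hydrogen on an aromatic carbon), produced a 1.1-fold higher number from compound 1 to compound 2 (0.04 log units; within the scatter), so the two numbers are not told apart by this kind of measurement.

Compound 3 `O=C(CCCCCO)c1ccc(-c2ccc(F)cc2F)cc1` has a different core; the difference between the two cores is not broken down here. In this assay, within the data shown here, compound 3 gives 6000 nM, the lowest of the three numbers so far.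

Compound 4 `Cc1cc(C(=O)CCCCCO)ccc1-c1ccc(F)cc1F` is not yet measured. It differs from compound 3 by methyl in place of hydrogen on an aromatic carbon. Among the measured compounds shown here, this is the same kind of change as the one from compound 1 to compound 2, though the place differs: there the new methyl sat ortho to a large group, here it sits ortho to a group of 8 heavy atoms and meta to a group of 8 heavy atoms. The step from compound 3 to compound 4 is expected to be about a 1.1-fold higher number from compound 3 to compound 4 (0.03 log units; within the scatter), resting on the earlier step of a 1.1-fold higher number from compound 1 to compound 2 (0.04 log units; within the scatter). Compound 4 is therefore estimated at 6500 nM, likely between 3000 nM and 14000 nM.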

Compound 4, half-maximal inhibitory concentration: 8000 nM
Compound 4: the middle estimate sits 1.2-fold (0.09 log units) below what was measured, within the range that was stated.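

On the second core, methyl in place of hydrogen gives a 1.3-fold higher number from compound 3 to compound 4 (0.12 log units; within the scatter) in this assay, so this kind of measurement does not tell these two numbers apart. Set beside the earlier step, the same change gives a similar result on both cores: the same change on two cores in this assay, a 1.1-fold higher number (0.04 log units; within the scatter) from compound 1 to compound 2 and a 1.3-fold higher number (0.12 log units; within the scatter) from compound 3 to compound 4, 1.2-fold (0.09 log units) apart, within the scatter of two such steps. This shows that across these two pairs the change carried over from one core to the other without a step that can be told from the scatter, even though the methyl sits in a different place in each pair, but two pairs do not make a rule for other cores or other places on the ring, and they give no reason for the result.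

On these data alone, it remains open whether ethyl or chlorine in the place of the methyl would behave the same way. Also open, as far as these compounds go, is what an amine or a carboxylic acid in place of the hydroxyl of the chain, or a longer chain, would do to the number on either core.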